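The source may report more compounds than this note shows. Statements on the series, on what has been measured and on what is new or still open speak of the compounds shown alone.

For the measured compounds named here, compound 1, with the structure `Cc1ccc2[nH]c(=O)c(CN(Cc3ccc(O)cc3)Cc3ccc(C(C)(C)C)cc3)cc2c1`, is the one compound in this small set that gives an actual number: in a toxicity assay on MDCK cells (Canis lupus familiaris) for cytotoxicity, read by crystal violet staining, with a stated time of 48 h (on this read-out lower numbers stand for higher toxicity in this test and higher numbers for lower toxicity in this test), compound 1 gives 4900 nM. Compound 2, with the structure `CCc1ccc2[nH]c(=O)c(CN(Cc3ccc(O)cc3)Cc3ccc(C(C)(C)C)cc3)cc2c1`, is its closest relative, and in this assay compound 2 reaches only the limit of the assay, > 10000 nM, which is a limit and not a number. Going by these compounds, the step from compound 1 to compound 2 therefore reads as an at least 2.0-fold higher number from compound 1 to compound 2 (0.30 log units; that floor lies within the scatter), and this is evidenced only by the limit of > 10000 nM in this assay, at which 1 of the 2 values shown sits, so its true size stays open.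

Compound 3, with the structure `CCCCOc1ccc(CN(Cc2ccc(C(C)(C)C)cc2)Cc2cc3cc(C)ccc3[nH]c2=O)cc1`, differs from compound 1 by butyl in place of hydrogen on an oxygen on an aromatic ring. Going by the values given here, no measured step alters that same oxygen, so the single step on record, the one from compound 1 to compound 2, bears on it only loosely, and it was itself no larger than the scatter might allow. The expectation for compound 3 is accordingly a number close to that of compound 1, with the estimated step of a 1.2-fold lower number from compound 1 to compound 3 (0.09 log units; within the scatter). In this assay compound 3 is expected to give about 4000 nM, estimated within the range from 1500 nM to 10000 nM.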

Compound 3, half-maximal cytotoxic concentration: > 5000 nM
Compound 3 gave a limit, no number (the forecaster's own chance of this, stated with the estimate: 25%); at least 1.2-fold (0.09 log units) between middle value and limit.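

In this assay, for the compounds shown here, the change from 4-hydroxybenzyl to 4-butoxybenzyl gives the first reading at this oxygen on an aromatic ring, and the step is an at least 1.0-fold higher number from compound 1 to compound 3 (0.00 log units; that floor lies within the scatter), which puts a floor on the change but no size. Compound 3 gives > 5000 nM, which is a limit of the assay and not a number, so the butyl group on this oxygen leaves the read-out at a limit, as the methyl in place of hydrogen on the chain carbon did for compound 2. Whether butyl moves the number at all therefore cannot be said, because the reading for compound 3 ends at a limit: the limit of > 5000 nM in this assay, at which 1 of the 3 values shown sits.

The compounds shown leave open what a shorter chain such as methyl or a longer chain such as octyl would give on this same oxygen. They also leave open whether a butyl chain ending in an amine or a carboxylic acid would return an actual number in this assay rather than a limit.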